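Changing the Group on a Ring Nitrogen: An Estimate

This account rests on a few compounds, and the source may have more. Where it says the series, first, only, none or still open, it means among the compounds named here.

In a functional assay on MCF7 cells (Homo sapiens) for cytotoxicity, read by MTT assay, with a stated time of 24 h, tested at 80 ug/mL (a lower number here means a weaker effect, a higher number a stronger effect of the compound at the concentration tested), compound 1 `Cc1ccc2oc(SCC(=O)Nc3ccc(-c4nc(-c5ccccc5)c(-c5ccccc5)n4C)cc3)nc2c1` gives 65.1%.
Compound 2 `CN1CCN(CC(=O)Nc2ccc(-c3nc(-c4ccccc4)c(-c4ccccc4)n3C)cc2)CC1` gives 50.3%.

Among the measured compounds shown here, compound 2 has the lower of these two numbers; the one measured step is a number 14.8 percentage points lower from compound 1 to compound 2 (beyond the scatter). Compound 3 `CN(C)/C=C/N1CCN(CC(=O)Nc2ccc(-c3nc(-c4ccccc4)c(-c4ccccc4)n3C)cc2)CC1` differs from compound 2 in one place: 2-(dimethylamino)ethenyl in place of methyl on an amine nitrogen in a ring. That measured step exchanges a different group at a different place, so it does not bear directly on this change, and the two values show only what swapping the group on the chain carbon did. With nothing that speaks to a change on the ring nitrogen, for compound 3 no step beyond the scatter is expected, a number 1.7 percentage points higher from compound 2 to compound 3 (within the scatter). Compound 3 is therefore estimated at 52%, between 38% and 66%.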

Compound 3, a percentage reported as activity, at one concentration (the size of the read-out at that concentration, not a potency): 34.7%
Estimate against measurement, compound 3: 17.3 percentage points above, outside the stated range (below it).
By their numbers in this assay, from the lowest: compound 3; then compound 2; then compound 1.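

The group on the ring nitrogen does matter in this assay: 2-(dimethylamino)ethenyl in place of methyl gives a number 15.6 percentage points lower from compound 2 to compound 3 (beyond the scatter), so this position is not neutral to change. With 4-(2-(dimethylamino)ethenyl)piperazin-1-yl in place of (5-methyl-1,3-benzoxazol-2-yl)sulfanyl on the chain carbon, the result is a number 30.4 percentage points lower from compound 1 to compound 3 (beyond the scatter). No evidence at hand accounts for the drop at the ring nitrogen.

From the compounds shown here alone, it remains open whether the double bond, the dimethylamino end or the added length matters most. A saturated 2-(dimethylamino)ethyl group or a plain ethyl group on that nitrogen would help separate these.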